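Benzyloxy for bromo on the phenoxy ring of compound 2

The compounds below may be only part of what the source reports. "The series", "measured", "known", "first", "only" and "open" are said of these compounds alone.

Measured compounds:
- compound 1 `Cc1cccc(Nc2ncc(Br)c(Oc3cccc(F)c3)n2)c1`: 19400 nM
- compound 2 `Cc1cccc(Nc2ncc(Br)c(Oc3ccc(Br)cc3)n2)c1`: 18600 nM

Compound 2 `Cc1cccc(Nc2ncc(Br)c(Oc3ccc(Br)cc3)n2)c1` gives 18600 nM in a functional assay on U-937 cells (Homo sapiens) for antiproliferative activity, read by MTT assay, with a stated time of 24 h (a lower number here means a stronger inhibitor, a higher number a weaker inhibitor), and compound 1 `Cc1cccc(Nc2ncc(Br)c(Oc3cccc(F)c3)n2)c1` gives 19400 nM. For the measured compounds named here, the only measured step, a 1.0-fold lower number from compound 1 to compound 2 (0.02 log units; within the scatter), changes the substituent on the phenoxy ring and leaves the number essentially where it was, so neither compound can be called stronger than the other.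

Compound 3 `Cc1cccc(Nc2ncc(Br)c(Oc3ccc(OCc4ccccc4)cc3)n2)c1` is not yet measured. It differs from compound 2 by benzyloxy in place of bromo on an aromatic carbon. Going by the values given here, no measured pair covers a change of this kind; the one step in hand, a 1.0-fold lower number from compound 1 to compound 2 (0.02 log units; within the scatter), only shows that a small swap on that ring did not move the number beyond the scatter. On that narrow basis, the step of a 1.2-fold lower number from compound 2 to compound 3 (0.09 log units; within the scatter) is expected to be small, though the larger group entering leaves room for a shift in either direction. Compound 3 is therefore estimated at 15000 nM, with a range of 5000 nM to 50000 nM.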

Compound 3, half-maximal inhibitory concentration: > 50000 nM
Compound 3 was reported as a limit; the forecaster's own chance of this, stated with the estimate: 15%; middle value at least 3.3-fold (0.52 log units) from the limit.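

In this assay compound 3 gives > 50000 nM, which is a limit of the assay and not a number. For the compounds shown here, the step, an at least 2.6-fold higher number from compound 2 to compound 3 (0.42 log units; beyond the scatter), is the first change on the phenoxy ring in this set to pass the scatter, whereas the earlier one, a 1.0-fold lower number from compound 1 to compound 2 (0.02 log units; within the scatter), did not, which shows that the number at this aromatic carbon does respond to what is placed there: benzyloxy, with its 8 heavy atoms and its added aromatic ring, gives a weaker inhibitor than bromo. The real size of this loss cannot be read, and the reason lies in where the value of compound 3 stands: the limit of > 50000 nM in this assay, at which 1 of the 3 values shown sits.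

From the compounds shown here alone, what remains open is which part of benzyloxy goes with the loss, the oxygen, the methylene or the added ring, a question that methoxy or a phenyl group set directly on the same carbon would help to separate. Going by these compounds, it is also open whether a hydroxyl, an amine or a carboxylic acid at this carbon would leave the number near that of compound 2 or move it in either direction.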